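This account rests on a few compounds, and the source may have more. Where it says the series, first, only, none or still open, it means among the compounds named here.

Within the data shown here, in a functional assay on KB cells (Homo sapiens) for antiproliferative activity, read by MTT assay, with a stated time of 72 h (a lower number here means a stronger inhibitor, a higher number a weaker inhibitor), compound 1 `COc1ccc(-c2ss/c(=N/O)c2-c2cc(OC)c(OC)c(OC)c2)cc1` gives 13700 nM and compound 2 `COc1ccc(-c2ss/c(=N/O)c2-c2cc(OC)c(OC)c(OC)c2)cc1N` gives 99 nM as the lower of the two numbers so far. Among the measured compounds shown here, that gap is the only measured step (a 140-fold lower number from compound 1 to compound 2 (2.14 log units; beyond the scatter)) and it goes with amino in place of hydrogen on an aromatic carbon. Compound 3 `CO/N=c1/ssc(-c2ccc(OC)c(N)c2)c1-c1cc(OC)c(OC)c(OC)c1` keeps that amino group and differs elsewhere (methyl in place of hydrogen on an oxygen) with methyl in place of hydrogen on an oxygen, hydroxy to methoxy, where the oxygen's other neighbour is a double-bonded nitrogen. For the measured compounds named here, no measured pair shows this change, so the size of the amino step does not carry over. The expectation therefore starts from compound 2 alone (99 nM) and the data give no firm direction. The expected change (a 1.5-fold higher number from compound 2 to compound 3 (0.18 log units; within the scatter)) is none beyond the scatter, though with wide uncertainty. Compound 3 is estimated at 150 nM with an expected range from 30 nM to 800 nM in this measurement.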

Compound 3, half-maximal inhibitory concentration: 4330 nM
For compound 3 the middle estimate is 29-fold (1.46 log units) below the measured one, outside the stated range (above it).
By their numbers in this assay, from the lowest: compound 2; then compound 3; then compound 1.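

In this assay, replacing hydroxy with methoxy, on an oxygen whose other neighbour is a double-bonded nitrogen, comes with a 44-fold higher number from compound 2 to compound 3 (1.64 log units; beyond the scatter). Among these compounds, this position is therefore sensitive to a single added methyl, which the earlier pair could not show, as its only change was on an aromatic carbon. Compound 3 also shows that keeping the amino group does not by itself hold the number near that of compound 2. Nothing available explains this rise.

On these data alone, it remains open whether the rise belongs to methyl in particular or to any replacement of that hydrogen, a question that an ethyl group, a longer chain or an acetyl group on the same oxygen would address. Also open, as far as these compounds go, is whether the same methyl has a similar effect when the aromatic amino group is absent.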